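The source may hold more compounds than are shown below. What is called first, only, known or untested is meant among the compounds shown, and "the series" means these compounds.

Compound 1 `Cc1nn([C@H](C)c2ccc(Cl)cc2Cl)c2nc(N3CC[C@H](N4CCC[C@H]4CCS(C)(=O)=O)[C@H](C)C3)cnc12` and compound 2 `Cc1nn([C@H](C)c2ccc(Cl)cc2Cl)c2nc(N3CC[C@H](N4CCC[C@H]4C(=O)O)[C@H](C)C3)cnc12` share a core with compound 3 `Cc1nn([C@H](C)c2ccc(Cl)cc2Cl)c2nc(N3CC[C@H](N4CCC[C@H]4CCC#N)[C@H](C)C3)cnc12` and differ from it only in the group carried on the pyrrolidine. For compound 1 the result in an assay on CCRF-CEM cells for antagonist activity at C-C chemokine receptor type 4 (Homo sapiens), read by CellTiter-Glo, with stated times of 30 min and 60 min, in the presence of a further agent that is not named here (a lower number here means a stronger inhibitor, a higher number a weaker inhibitor), is "not determined" (no result reported), and for compound 2 the result in this assay is "not determined" (no result reported). Among the measured compounds shown here, compound 3 is therefore the one member of this group with a number: in this assay compound 3 gives 865 nM. For the measured compounds named here, with nothing else measured, compound 3 stands alone, neither strong nor weak by comparison, and no step between measured compounds can be drawn.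

Compound 4 `Cc1nn([C@H](C)c2ccc(Cl)cc2Cl)c2nc(N3CC[C@H](N4CCC[C@H]4CO)[C@H](C)C3)cnc12` is the next entry. The change from compound 3 to compound 4 is hydroxy in place of cyanomethyl on a saturated chain carbon bound to a saturated ring carbon. The 2-cyanoethyl chain is cut back to a hydroxymethyl, so the pyrrolidine loses two chain carbons and a nitrile and gains a hydroxy with one hydrogen-bond donor. Going by the values given here, because the only anchor is compound 3 at 865 nM, the size of this step can only be guessed; a modest loss, at or just beyond the usual scatter, is expected rather than a gain, since no measured pair here shows a shortened chain helping. The step is expected to read a 1.7-fold higher number from compound 3 to compound 4 (0.24 log units; within the scatter). Compound 4 is estimated at 1500 nM in this assay, within a range from 400 nM to 6000 nM.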

Compound 4, half-maximal inhibitory concentration: 151 nM
Estimate against measurement, compound 4: 9.9-fold (1.00 log units) above, outside the stated range (below it).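

In this assay, among the compounds shown here, replacing the 2-cyanoethyl chain on the pyrrolidine with hydroxymethyl gives a 5.7-fold lower number from compound 3 to compound 4 (0.76 log units; beyond the scatter), the first sign that a change of group at this place, on a saturated chain carbon bound to a saturated ring carbon, can move the result beyond the usual scatter. The change removes a nitrile, shortens the chain and brings in a hydrogen-bond donor all at once, so this single step cannot assign the gain to any one of these. Nothing measured here gives a reason for the step.

The compounds shown leave open whether the hydroxy or the shorter chain matters more: a 2-hydroxyethyl chain would keep the hydroxy on a longer chain, and a methoxymethyl group would keep the chain length of hydroxymethyl without the hydroxy hydrogen. Also open, from the compounds shown here alone, is how an aminomethyl group would compare, and compound 1 and compound 2 have no reported result, so the methylsulfonyl-bearing chain and the carboxylic acid add nothing to the picture at this position.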